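The compounds below may be only part of what the source reports. "The series", "measured", "known", "first", "only" and "open" are said of these compounds alone.

In an ADME assay on PC-3 cells (Homo sapiens) for cytotoxicity, read by WST assay, tested at 100 uM (on this read-out lower numbers stand for less inhibition and higher numbers for more inhibition at the one concentration tested (going by the name of the read-out)), three compounds have been measured:
compound 1, `O=C(Nc1ccc(Cl)cn1)C1CCCN(C(=O)c2cc(C(F)(F)F)cc(C(F)(F)F)c2)C1`, gives 0%;
compound 2, `CSc1cccc(C(=O)N2CCCC(C(=O)Nc3ccc(Cl)cc3)C2)c1`, gives 0%;
compound 3, `O=C(c1ccccc1)c1cccc(NC(=O)C2CCCN(C(=O)c3cc(C(F)(F)F)cc(C(F)(F)F)c3)C2)c1`, gives 0%.

On these numbers compound 2 stands level with compound 1 and with compound 3: the three read-outs agree at the digits shown, and none of the gaps between them goes beyond the usual scatter of such measurements. Within the data shown here, nothing among the measured compounds separates one from another.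

Compound 4, `COCc1cccc(C(=O)N2CCCC(C(=O)Nc3ccc(Cl)cc3)C2)c1`, is not yet measured. It differs from compound 2 in one place: methoxymethyl in place of methylsulfanyl on an aromatic carbon. Both the leaving and the entering group are small, without a ring, each with one hydrogen-bond acceptor and no donor, and the change sits on an aromatic carbon of a six-membered aromatic ring of carbon only.

Among the measured compounds shown here, no step between two measured compounds is available to gauge this change, so the expectation rests on the flat picture alone. Because compound 2 gives 0% and the other measured compounds sit at the same level, the expected step is no change at the digits printed from compound 2 to compound 4 (within the scatter), none beyond the scatter. For compound 4 the estimated value in this assay is 0%, with a range from 0% to 12%.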

Compound 4, a percentage reported as inhibition, at one concentration (the size of the read-out at that concentration, not a potency): 0%
The estimate for compound 4 equals the measured number at the digits printed; low and high end bracket the measured number.
By their numbers in this assay, from the lowest: compounds 1, 2, 3 and 4 (each within the scatter of the next).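

In this assay, among these compounds, the change from 3-(methylsulfanyl)phenyl to 3-(methoxymethyl)phenyl gives no change at the digits printed from compound 2 to compound 4 (within the scatter) and is the first step here that can be read at a single changed place. It shows that this position, on an aromatic carbon meta to a large group, can carry methoxymethyl instead of methylsulfanyl without the read-out moving beyond the usual scatter at the one concentration tested. No measurement here offers an explanation for this result.

With a single step and every compound reading the same, the compounds shown do not reveal whether any group at this position can move the read-out. An amine, a carboxylic acid or a longer chain such as 2-methoxyethyl on this carbon remains an open question.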